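Swapping the halogen on the anilide ring of a thiazolidinone

A few compounds are considered here, and "the series" means these few. Any claim that something is new, unique, unknown or untested is made for them only; others in the source may bear on it.

Compound 1, `O=C1N/C(=N/c2ccc(Cl)cc2)S/C1=C\c1ccccn1`: 34.8%
Compound 2, `O=C1N/C(=N/c2ccccc2Cl)S/C1=C\c1ccccn1`: 26.2%

Within the data shown here, in a functional assay on the whole organism (strain Wistar) for inhibition, with Rattus norvegicus as the target, read by paw edema, with stated times of 30 min and 120 min, at a dose of 10 mg/kg by the oral route (on this read-out higher numbers stand for more inhibition at the one dose given (going by the name of the read-out) and lower numbers for less inhibition), compound 2 gives the lower of the two numbers so far, yet it lies within the scatter of compound 1, so the two cannot be ranked. Among the measured compounds shown here, the single measured step, a number 8.6 percentage points lower from compound 1 to compound 2 (within the scatter), is itself within the scatter. Compound 3 `O=C1N/C(=N/c2ccc(Br)cc2)S/C1=C\c1ccccn1` carries the change (4-bromophenyl in place of 2-chlorophenyl on a double-bonded nitrogen). For the measured compounds named here, this change largely undoes that earlier step, returning to the pattern of compound 1 while replacing chlorine with bromine; no measured compound tells how bromine alone behaves here. Because a number 8.6 percentage points lower from compound 1 to compound 2 (within the scatter) was within the scatter, the step of a number 6.8 percentage points higher from compound 2 to compound 3 (within the scatter) is expected to be small, upward if anything, and not beyond the scatter. Compound 3 is therefore estimated at 33%, with a range from 20% to 46%.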

Compound 3, a percentage reported as inhibition, in the whole organism at one dose (the size of the read-out at that dose, not a potency): 30.4%
Compound 3: middle estimate off by 2.6 percentage points, on the high side; the measured number falls inside the stated range.
By their numbers in this assay, from the lowest: compounds 2, 3 and 1 (each within the scatter of the next).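

In this assay, bromo in place of chloro on an aromatic carbon gives a number 4.4 percentage points lower from compound 1 to compound 3 (within the scatter) and so leaves this pair, which differs only in the halogen, unranked at the one dose given. The other new step, a number 4.2 percentage points higher from compound 2 to compound 3 (within the scatter) when 4-bromophenyl replaces 2-chlorophenyl, changes both the halogen and its place on the ring, so it cannot be split into two separate contributions. No measurement is available that would explain these numbers.

The compounds shown leave open whether 2-bromophenyl would read like 2-chlorophenyl, which would separate the halogen from its place on the ring. They also leave open how an unsubstituted phenyl, a methoxy group or an amine on this ring would behave, and whether any such group would move the number beyond the scatter.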